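Moving a methyl group on a weak growth inhibitor

A few compounds are considered here, and "the series" means these few. Any claim that something is new, unique, unknown or untested is made for them only; others in the source may bear on it.

In a functional assay on HCT-15 cells (Homo sapiens) for inhibition, read by sulforhodamine B assay (on this read-out higher numbers stand for weaker inhibition of growth and lower numbers for stronger inhibition of growth), compound 1 (`O=C(CCC1=CCCN(Cc2ccc(F)cc2)C1=O)NO`) gives 9960 nM. Compound 2 (`Cc1cccc(CN2CCC=C(CCC(=O)NO)C2=O)c1`) stands at > 10000 nM, which is a limit of the assay and not a number. Going by the values given here, the one measured step bears on what follows: a number no lower from compound 1 to compound 2 (the limit leaves the size open). Going by these compounds, its size stays open, and the data show (the limit of > 10000 nM in this assay, at which 1 of the 2 values shown sits). Compound 3 (`Cc1ccccc1CN1CCC=C(CCC(=O)NO)C1=O`) has 2-methylphenyl in place of 3-methylphenyl on a saturated chain carbon bound to an amide-type nitrogen in a ring. The expected move in this assay is none beyond the scatter, an estimated a number no higher from compound 2 to compound 3 (the limit leaves the size open). Compound 3 is estimated at 10000 nM, with an expected range of 4500 nM to 22000 nM.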

Compound 3, concentration for 50% growth inhibition: > 10000 nM
Compound 3: no number, only a limit (the forecaster's own chance of this, stated with the estimate: 55%); the middle value sits exactly at the limit.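

In this assay compound 3 stands at > 10000 nM, which is a limit of the assay and not a number. Whether moving the methyl group from 3-methylphenyl to 2-methylphenyl changes growth inhibition cannot be read, because compound 2 and compound 3 both sit at the same limit: the limit of > 10000 nM in this assay, at which 2 of the 3 values shown sit. The only readable result for this change is a second methylphenyl replacement of 4-fluorophenyl, with a number no lower from compound 1 to compound 3 (the limit leaves the size open). Going by these compounds, what stays open is whether an aminophenyl or a methoxyphenyl at this place would bring a value clear of the limit.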